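Aryl ketone hydroxamates: ring methoxy and chain length

This account rests on a few compounds, and the source may have more. Where it says the series, first, only, none or still open, it means among the compounds named here.

Measured so far in an assay on isolated protein for inhibition of histone deacetylase 8 (Homo sapiens); a lower number here means a stronger inhibitor, a higher number a weaker inhibitor:
compound 1, `O=C(CCCCCC(=O)c1ccccc1)NO`: 1500 nM
compound 2, `O=C(CCCCCCCC(=O)c1ccccc1)NO`: 65 nM
compound 3, `COc1ccccc1C(=O)CCCCCCCC(=O)NO`: 95 nM

Compound 2 gives the lowest of the three numbers in this assay. Compound 3 sits within the usual scatter of it, as a 1.5-fold higher number from compound 2 to compound 3 (0.16 log units; within the scatter) shows, whereas compound 1 lies far off, as a 23-fold lower number from compound 1 to compound 2 (1.36 log units; beyond the scatter) shows. Compound 4, `COc1ccc(C(=O)CCCCCCCC(=O)NO)cc1`, differs from compound 2 by methoxy in place of hydrogen on an aromatic carbon. Going by the values given here, the only measured step that bears on this change is a 1.5-fold higher number from compound 2 to compound 3 (0.16 log units; within the scatter), a methoxy entering the same ring at a different aromatic carbon, and it stayed within the scatter. The chain step a 23-fold lower number from compound 1 to compound 2 (1.36 log units; beyond the scatter) concerns a different part of the molecule and gives no guidance here. No step beyond the scatter is therefore expected in this assay for compound 4. Compound 4 is expected to give about 80 nM, within 35 nM to 180 nM, which means an expected step of a 1.2-fold higher number from compound 2 to compound 4 (0.09 log units; within the scatter).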

Compound 4, half-maximal inhibitory concentration: 15 nM
For compound 4 the middle estimate is 5.3-fold (0.73 log units) above the measured one; the whole stated range lies above it.
By their numbers in this assay, from the lowest: compound 4; then compounds 2 and 3 (each within the scatter of the next); then compound 1.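

In this assay, methoxy in place of hydrogen para to a large group is not a neutral change: the step is a 4.3-fold lower number from compound 2 to compound 4 (0.64 log units; beyond the scatter) and not the small shift seen for compound 3. The same group on a different aromatic carbon stayed within the scatter of compound 2, so in this pair the size of the step depends on which ring carbon carries the methoxy. No evidence on hand bears on this result. As far as these compounds go, whether an ethoxy, a hydroxyl or an amine at this carbon gives a similar step stays open. So does whether the methoxy step carries over to the shorter chain of compound 1.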